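The source may hold more compounds than are shown below. What is called first, only, known or untested is meant among the compounds shown, and "the series" means these compounds.

Measured so far in a functional assay on HT-29 cells (Homo sapiens) for antiproliferative activity, read by sulforhodamine B assay, with a stated time of 72 h; on this read-out lower numbers stand for stronger inhibition and higher numbers for weaker inhibition:

Compound 1 `Fc1ccccc1NC(=S)N/N=C/c1ccc2ccccc2n1`: > 100000 nM (a limit of the assay, not a number).
Compound 2 `NC(=S)N/N=C/c1cc2ccccc2s1`: 99200 nM.
Compound 3 `CC(C)c1cccc(C(C)C)c1NC(=S)N/N=C/c1ccc2ccccc2n1`: 20700 nM.
Compound 4 `COc1ccc(NC(=S)N/N=C/c2ccc3ccccc3n2)cc1`: not yet measured.

Compound 1 stands at the limit of this assay; of the three values shown, it is the one that sits at the limit of > 100000 nM in this assay, at which 1 of the 3 values shown sits, so its own place on the scale is not known beyond that. Compound 3, which carries the same core, gives a number in this assay, and compound 2, with a different core, also gives a number. Among the measured compounds shown here, no step between two measured compounds differing in one place is available.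

The change from compound 1 to compound 4 is 4-methoxyphenyl in place of 2-fluorophenyl on an amide-type nitrogen. For the measured compounds named here, the only measured compound in this assay that shares the core of compound 1 and gives a number is compound 3 at 20700 nM, so the range into which compound 4 may fall is wide. The step of an at least 1.6-fold lower number from compound 1 to compound 4 (0.22 log units; that floor lies within the scatter) is an estimate, expected to lie toward stronger inhibition, though a result at the limit remains plausible. Compound 4 is expected to give about 60000 nM in this assay, within 15000 nM to 200000 nM.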

Compound 4, half-maximal inhibitory concentration: 82300 nM
For compound 4 the middle estimate is 1.4-fold (0.14 log units) below the measured one; the range from low to high includes it.
By their numbers in this assay, from the lowest: compound 3; then compounds 4 and 2 (each within the scatter of the next). At a limit, above all of these: compound 1.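

In this assay compound 1 stands at > 100000 nM, a limit of the assay and not a number. With 4-methoxyphenyl in place of 2-fluorophenyl on the amide-type nitrogen whose other neighbour is the thiocarbonyl carbon, the series has its first readable step at a single place, an at least 1.2-fold lower number from compound 1 to compound 4 (0.08 log units; that floor lies within the scatter), so the change yields a number on the shared core but shows no gain beyond the scatter. Only the floor of this step can be read, and its true size stays open, because compound 1 has no number of its own: the limit of > 100000 nM in this assay, at which 1 of the 4 values shown sits.

The pair changes both the substituent and the place it occupies on the phenyl ring, so the two effects cannot be separated with compound 1 and compound 4 alone. Going by these compounds, how an unsubstituted phenyl, an amine or a carboxylic acid on that ring would read in this assay remains open. On these data alone, compound 3 gives 20700 nM, and whether any such group gives a lower number than compound 3 remains open as well.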